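The compounds below may be only part of what the source reports. "The series", "measured", "known", "first", "only" and "open" are said of these compounds alone.

Three compounds carrying a shared sulfonamide-bearing core were tested in a functional assay on HepG2 cells (Homo sapiens) for antiproliferative activity, read by MTT assay, with a stated time of 72 h; on this read-out lower numbers stand for stronger inhibition and higher numbers for weaker inhibition. Compound 1 `CC(C)N1C(=O)COc2ccc(-c3cnc(Cl)c(NS(=O)(=O)c4ccc(F)cc4)c3)cc21` gives 21500 nM. Compound 2 `O=C1COc2ccc(-c3cnc(Cl)c(NS(=O)(=O)c4ccc(F)cc4)c3)cc2N1c1ccc(Cl)cc1` gives 33900 nM. Compound 3 `COc1ncc(-c2ccc3c(c2)N(c2ccc(Cl)cc2)C(=O)CO3)cc1NS(=O)(=O)c1ccc(F)cc1` gives 17900 nM. Between compound 2 and compound 1 the change is isopropyl in place of 4-chlorophenyl on an amide-type nitrogen in a ring, and it brought a 1.6-fold lower number from compound 2 to compound 1 (0.20 log units; within the scatter). Between compound 2 and compound 3 the change is methoxy in place of chloro on an aromatic carbon, giving a 1.9-fold lower number from compound 2 to compound 3 (0.28 log units; within the scatter). Compound 3 and compound 1 are within the scatter of each other, so no order among the three can be claimed.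

Compound 4 `COc1ncc(-c2ccc3c(c2)N(C(C)C)C(=O)CO3)cc1NS(=O)(=O)c1ccc(F)cc1` has not yet been measured in this assay. Within the data shown here, it differs from compound 3 by isopropyl in place of 4-chlorophenyl on an amide-type nitrogen in a ring; this is the same change as the one from compound 2 to compound 1, with the same surroundings, but set on the core of compound 3, which differs from the core of compound 2 by methoxy in place of chloro on an aromatic carbon. Because the earlier step was a 1.6-fold lower number from compound 2 to compound 1 (0.20 log units; within the scatter), a step of similar size, a 1.5-fold lower number from compound 3 to compound 4 (0.17 log units; within the scatter), is expected for compound 4. Compound 4 is therefore estimated at 12000 nM.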

Compound 4, half-maximal inhibitory concentration: 37200 nM
The estimate for compound 4 lay 3.1-fold (0.49 log units) below the measured number; measured number outside the range, above it.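

In this assay, isopropyl in place of 4-chlorophenyl on the amide-type nitrogen gave a 2.1-fold higher number from compound 3 to compound 4 (0.32 log units; beyond the scatter), so the step seen on the chloro core did not carry over to the methoxy core, where it ran the other way: the same change on two cores in this assay, a 1.6-fold lower number (0.20 log units; within the scatter) from compound 2 to compound 1 and a 2.1-fold higher number (0.32 log units; beyond the scatter) from compound 3 to compound 4, 3.3-fold (0.52 log units) apart, beyond the scatter of two such steps. Methoxy in place of chloro gave a 1.7-fold higher number from compound 1 to compound 4 (0.24 log units; within the scatter), a step within the scatter on its own, yet it still differs from the same change made on the core carrying 4-chlorophenyl: the same change on two cores in this assay, a 1.9-fold lower number (0.28 log units; within the scatter) from compound 2 to compound 3 and a 1.7-fold higher number (0.24 log units; within the scatter) from compound 1 to compound 4, 3.3-fold (0.52 log units) apart, beyond the scatter of two such steps. Across these four compounds the two changes therefore do not add independently, but this rests on a single pair of changes in one assay and does not show why the outcome of one depends on the other.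

The compounds shown leave open whether the reversal would also appear with other groups on the amide-type nitrogen, such as cyclopropyl, benzyl or a longer alkyl chain. They also leave open how an amine or a nitrile would behave in place of the chloro or methoxy group.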